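A few compounds are considered here, and "the series" means these few. Any claim that something is new, unique, unknown or untested is made for them only; others in the source may bear on it.

Three compounds share one core and differ only in a single group on an aromatic carbon. Compound 1 `Cn1nc2c(=O)n(CC3(O)CCN(Cc4ccc(-c5ccco5)cc4Cl)CC3)cnc2c1-c1ccc(C2(N)CC2)cc1` carries 1-aminocyclopropyl there, and in an assay on isolated protein for inhibition of ubiquitin carboxyl-terminal hydrolase 7 (Homo sapiens), with stated times of 30 min and 2 h (a higher number here means a weaker inhibitor, a lower number a stronger inhibitor), compound 1 gives 66.1 nM. Compound 2 `Cn1nc2c(=O)n(CC3(O)CCN(Cc4ccc(-c5ccco5)cc4Cl)CC3)cnc2c1-c1ccc(C(N)=O)cc1` carries carbamoyl, and in this assay compound 2 gives 80.8 nM. Compound 3 `Cn1nc2c(=O)n(CC3(O)CCN(Cc4ccc(-c5ccco5)cc4Cl)CC3)cnc2c1-c1ccc(CNS(C)(=O)=O)cc1` carries (methanesulfonamido)methyl, and in this assay compound 3 gives 65.3 nM. On the numbers shown compound 3 sits nearest compound 1 and furthest from compound 2, but both gaps, a 1.0-fold lower number from compound 1 to compound 3 (0.01 log units; within the scatter) and a 1.2-fold lower number from compound 2 to compound 3 (0.09 log units; within the scatter), lie within the scatter, as does a 1.2-fold higher number from compound 1 to compound 2 (0.09 log units; within the scatter); the three groups cannot be told apart on these data.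

Compound 4 `CN(C)Cc1ccc(-c2c3ncn(CC4(O)CCN(Cc5ccc(-c6ccco6)cc5Cl)CC4)c(=O)c3nn2C)cc1` has not yet been measured. Relative to compound 3 the change is dimethylamino in place of methanesulfonamido on a saturated chain carbon bound to an aromatic carbon. Among the measured compounds shown here, no measured step involves dimethylamino. For the measured compounds named here, the steps that bear on it are the three exchanges of the group on the aromatic carbon among compounds 1, 2 and 3, and each of them stayed within the scatter. On that basis no step beyond the scatter is expected in this assay, in either direction, and the expected step is a 1.0-fold lower number from compound 3 to compound 4 (0.00 log units; within the scatter). Compound 4 is therefore estimated at 65 nM, with a range of 33 nM to 130 nM.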

Compound 4, half-maximal inhibitory concentration: 131 nM
Estimate against measurement, compound 4: 2.0-fold (0.30 log units) below; measured number outside the range, above it.
By their numbers in this assay, from the lowest: compounds 3, 1, 2 and 4 (each within the scatter of the next).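

In this assay, a fourth group at this place stays within the scatter of all three earlier groups (a 2.0-fold higher number from compound 3 to compound 4 (0.30 log units; within the scatter); a 1.6-fold higher number from compound 2 to compound 4 (0.21 log units; within the scatter); a 2.0-fold higher number from compound 1 to compound 4 (0.30 log units; within the scatter)), so the series still shows no step beyond the scatter at this position. These new steps are wider than any step among compounds 1, 2 and 3, yet the change from methanesulfonamido to dimethylamino, on a saturated chain carbon bound to an aromatic carbon, takes the heavy-atom count from 5 to 3 and the hydrogen-bond donor count from 1 to 0 without a step that can be told apart from repeat measurement. No accompanying data speak to what lies behind these numbers.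

Still open, going by these compounds, is whether any group at this place gives a step beyond the scatter in this assay, for instance a carboxylic acid, or a longer chain ending in dimethylamino. All four compounds share the rest of the structure and are read in this one assay, so the values say nothing about changes elsewhere on the shared core or about behaviour in any other test.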